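Methoxy count on the pendant ring and cytotoxicity

The source may hold more compounds than are shown below. What is called first, only, known or untested is meant among the compounds shown, and "the series" means these compounds.

Measured compounds:
compound 1, `COc1ccc(-c2cc(/C=C/C(=O)c3ccc(N)cc3)[nH]n2)cc1`: 99%
compound 2, `COc1cc(-c2cc(/C=C/C(=O)c3ccc(N)cc3)[nH]n2)cc(OC)c1OC`: 110%

In a functional assay on NCI/ADR-RES cells (Homo sapiens) for cytotoxicity, read by sulforhodamine B assay, with a stated time of 48 h, tested at 0.1 uM (a lower number here means a stronger effect, a higher number a weaker effect of the compound at the concentration tested), compound 2 gives 110%, the highest of the two numbers; the nearest is compound 1, which gives 99%, a gap beyond the usual scatter. Both numbers sit near full activity at this concentration. Compound 3, `COc1ccc(-c2cc(/C=C/C(=O)c3ccc(N)cc3)[nH]n2)cc1OC`, differs from compound 2 by hydrogen in place of methoxy on an aromatic carbon. Among the compounds with values here, no step between measured compounds is known for this change. The step from compound 2 to compound 3 is expected to be a number 6 percentage points lower from compound 2 to compound 3 (within the scatter), toward a lower number but within the scatter, because compound 1 gives 99% with fewer methoxy groups. Compound 3 is estimated at 104%, with a range from 92% to 116%.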

Compound 3, a percentage reported as activity, at one concentration (the size of the read-out at that concentration, not a potency): 104%
Compound 3: middle estimate and measured number agree at the digits printed; the range from low to high includes it.
By their numbers in this assay, from the lowest: compounds 1, 3 and 2 (each within the scatter of the next, the first and the last beyond it).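

In this assay, removing one methoxy gives a number 6 percentage points lower from compound 2 to compound 3 (within the scatter) and adding one gives a number 5 percentage points higher from compound 1 to compound 3 (within the scatter) as single-place changes on an aromatic carbon. Neither single step leaves the scatter, so among these compounds no single methoxy change is resolved at this concentration. Nothing at hand gives a reason for these steps. From the compounds shown here alone, whether a hydroxyl group, a fluorine atom or an amine on that aromatic carbon would move the read-out remains open. Also open, going by these compounds, is whether these steps hold at any other concentration.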